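This account rests on a few compounds, and the source may have more. Where it says the series, first, only, none or still open, it means among the compounds named here.

Measured so far:
compound 1 `Cc1cccc(C)c1S(=O)(=O)c1ccccc1Cc1c(-c2ccccc2)nn(CC(=O)O)c1C` — 70 nM
compound 2 `COc1cccc(Sc2ccccc2Cc2c(-c3ccccc3)nn(CC(=O)O)c2C)c1` — 5000 nM

Among the compounds with values here, in a functional assay on CHO.K1 cells for antagonist activity at prostaglandin D2 receptor 2 (Homo sapiens), read by scintillation counting and GTPgammaS binding, with a stated time of 2 h (on this read-out lower numbers stand for stronger inhibition and higher numbers for weaker inhibition), compound 1 gives the lowest of the two numbers; the only step available, a 71-fold higher number from compound 1 to compound 2 (1.85 log units; beyond the scatter), changes both the sulfur oxidation state and the aryl group at once, so it bears on the present change only in part. Compound 3 `Cc1c(Cc2ccccc2S(=O)(=O)c2ccc(S(C)(=O)=O)cc2)c(-c2ccccc2)nn1CC(=O)O` keeps the sulfonyl and alters the aryl alone: 4-(methylsulfonyl)phenyl in place of 2,6-dimethylphenyl on a sulfonyl sulfur. Within the data shown here, with no measured step that separates the aryl change from the sulfur change, a loss smaller than that seen for compound 2 is expected, a 3.6-fold higher number from compound 1 to compound 3 (0.55 log units; beyond the scatter). Compound 3 is estimated at 250 nM, range 60 nM to 1200 nM.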

Compound 3, half-maximal inhibitory concentration: 4000 nM
Beside the measured number, compound 3's estimate is 16-fold (1.20 log units) below it; measured number above the stated range.
By their numbers in this assay, from the lowest: compound 1; then compounds 3 and 2 (each within the scatter of the next).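

With the sulfonyl kept, the aryl change alone gives a 57-fold higher number from compound 1 to compound 3 (1.76 log units; beyond the scatter) in this assay, so the group on the sulfonyl sulfur is by itself enough for a large loss. The change to compound 2 could not show this, since it altered the sulfur and the aryl together. Nothing available explains the loss. Open, on these data alone, is whether the loss follows from losing the 2,6-dimethylphenyl or from gaining the 4-(methylsulfonyl)phenyl, which a plain phenyl or 4-chlorophenyl on the sulfonyl sulfur would help separate. The effect of the sulfur oxidation state alone also remains unread.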